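A few compounds are considered here, and "the series" means these few. Any claim that something is new, unique, unknown or untested is made for them only; others in the source may bear on it.

In a functional assay on CCRF-CEM cells (Homo sapiens) for antiproliferative activity, with a stated time of 72 h (a higher number here means a weaker inhibitor, a lower number a stronger inhibitor), compound 3 `OC[C@H]1O[C@@H](n2cnc3c(NCc4ccc(F)cc4F)ncnc32)[C@H](O)[C@@H]1O` holds the middle place at 7100 nM among the three measured compounds, with compound 1 `COc1ccccc1CNc1ncnc2c1ncn2[C@@H]1O[C@H](CO)[C@@H](O)[C@H]1O` at 3200 nM as the lowest number and compound 2 `OC[C@H]1O[C@@H](n2cnc3c(NCc4ccc(Cl)cc4Cl)ncnc32)[C@H](O)[C@@H]1O` at 86700 nM as the highest. Compound 4 `OC[C@H]1O[C@@H](n2cnc3c(NCc4ccc(F)cc4Cl)ncnc32)[C@H](O)[C@@H]1O` follows from compound 3 through chloro in place of fluoro on an aromatic carbon and carries chloro in place of fluoro on an aromatic carbon, ortho to a large group, so that 2,4-difluorobenzyl becomes 2-chloro-4-fluorobenzyl. The nearest evidence is a 12-fold lower number from compound 2 to compound 3 (1.09 log units; beyond the scatter) (a large step), which exchanges both chloro groups for fluoro groups at once. The steps of a 27-fold higher number from compound 1 to compound 2 (1.43 log units; beyond the scatter) and a 2.2-fold higher number from compound 1 to compound 3 (0.35 log units; beyond the scatter) start from 2-methoxyphenyl and bear on the change only indirectly. No measurement shows how the large step divides between the two ring positions, so compound 4 is expected to fall between compound 3 and compound 2. The expected move is a 3.2-fold higher number from compound 3 to compound 4 (0.51 log units; beyond the scatter) toward a higher number in this assay as a moderate step. Compound 4 is estimated at 23000 nM with an expected range from 8000 nM to 70000 nM as a working bracket.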

Compound 4, half-maximal inhibitory concentration: 20900 nM
The estimate for compound 4 lay 1.1-fold (0.04 log units) above the measured number, and the stated range covers the measured number.
By their numbers in this assay, from the lowest: compound 1; then compound 3; then compound 4; then compound 2.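

In this assay, chloro in place of fluoro at this ring carbon, ortho to a large group and with the other fluoro kept, gives a 2.9-fold higher number from compound 3 to compound 4 (0.47 log units; beyond the scatter), while the remaining exchange of chloro for fluoro gives a 4.1-fold lower number from compound 2 to compound 4 (0.62 log units; beyond the scatter), so both single changes lie beyond the scatter and neither alone accounts for the full difference between the difluoro and dichloro compounds. The 2-chloro-4-fluorophenyl group also stays behind 2-methoxyphenyl, with a 6.5-fold higher number from compound 1 to compound 4 (0.81 log units; beyond the scatter), so among the compounds shown, compound 1 keeps the lowest number. No accompanying measurement explains these steps.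

As far as these compounds go, how a nitrile or an amine would compare with chloro at this ring carbon remains open. Also open, from the compounds shown here alone, is whether a longer chain in place of the benzyl group would keep this order.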